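This account rests on a few compounds, and the source may have more. Where it says the series, first, only, none or still open, it means among the compounds named here.

Three compounds of this series have numbers in a functional assay on HCT-116 cells (Homo sapiens) for antiproliferative activity, read by sulforhodamine B assay, with a stated time of 72 h; a higher number here means a weaker inhibitor, a lower number a stronger inhibitor. Compound 1 `O=C(N[C@@H]1CNCC[C@H]1c1ccc(Cl)cc1)c1ccc(-c2ncnc3c2CCC3O)s1` gives 23000 nM in this assay. Compound 2 `CC(=O)NCC[C@@H]1C[C@@H](c2ccc(F)c(F)c2)[C@H](NC(=O)c2cc(-c3c(Cl)cnn3C)c(Cl)o2)CN1` gives 920 nM. Compound 3 `Cn1ncc(Cl)c1-c1cc(C(=O)N[C@@H]2CN[C@H](CCN3CCC(O)CC3)C[C@H]2c2ccc(Cl)c(Cl)c2)oc1Cl` gives 13700 nM, the second highest of the three numbers; compound 1 is nearest, and the two lie within the scatter of each other, so no order between them is claimed, while compound 2 sits furthest, beyond the scatter, with the lower number of the pair. Within the data shown here, no pair among the measured compounds differs in a single place, so no step has been computed.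

Compound 4 `Cn1ncc(Cl)c1-c1cc(C(=O)N[C@@H]2CN[C@H](CCO)C[C@H]2c2ccc(Cl)c(Cl)c2)oc1Cl` has not yet been measured. It differs from compound 3 in one place:

hydroxy in place of 4-hydroxypiperidin-1-yl on a saturated chain carbon, two bonds along the chain from a saturated ring carbon

Among the measured compounds shown here, with no measured step to go by, the expectation rests on compound 3 alone, and the step from compound 3 to compound 4 is expected to be small, with no direction beyond the scatter favoured: a 1.1-fold higher number from compound 3 to compound 4 (0.04 log units; within the scatter). Compound 4 is therefore estimated at 15000 nM in this assay, within a range from 5000 nM to 45000 nM.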

Compound 4, half-maximal inhibitory concentration: 340 nM
Beside the measured number, compound 4's estimate is 44-fold (1.64 log units) above it; the measured number lies below the stated range.
By their numbers in this assay, from the lowest: compound 4; then compound 2; then compounds 3 and 1 (each within the scatter of the next).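

Working from this assay, the exchange of 4-hydroxypiperidin-1-yl for hydroxy on the saturated chain carbon, two bonds along the chain from a saturated ring carbon, gives a 40-fold lower number from compound 3 to compound 4 (1.61 log units; beyond the scatter), so the number in this series depends strongly on what this position carries. Among these compounds, this is the only single-place step so far, and in it a group of 7 heavy atoms with a six-membered non-aromatic ring gives way to a single oxygen, while the hydrogen-bond donor count stays the same. Nothing measured here accounts for the size of the step.

One step cannot separate the loss of the ring from the loss of its nitrogen or of its size. As far as these compounds go, it also remains open whether a plain piperidin-1-yl, a primary amine, a carboxylic acid or a longer chain ending in hydroxy at this position would fall nearer compound 3 or compound 4.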